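A Shorter Amide Substituent on a Weakly Active Core

A few compounds are considered here, and "the series" means these few. Any claim that something is new, unique, unknown or untested is made for them only; others in the source may bear on it.

Going by the values given here, compound 2 `CCCSc1nc(Cl)c2c(n1)N(Cc1ccccc1)C(C(=O)NCCC1=CCc3ccccc31)N2` is one of three compounds measured in a functional assay on TE-1 cells (Homo sapiens) for antiproliferative activity, read by MTT assay, with a stated time of 72 h; a higher number here means a weaker inhibitor, a lower number a stronger inhibitor. In this assay compound 2 gives 30000 nM. Compound 1 `CCCSc1nc(Cl)c2c(n1)N(Cc1ccccc1)C(C(=O)N1CCN(Cc3ccccc3)CC1)N2` gives 48200 nM, and compound 3 `CCCSc1nc(Cl)c2c(n1)N(CCNC(=O)OC(C)(C)C)C(C(=O)N1CCN(C)CC1)N2` gives 51800 nM. The gaps between compound 2 and each of the other two lie within the usual scatter of repeated measurements, so none of the three can be set apart from the others. Compound 4 `CCCSc1nc(Cl)c2c(n1)N(Cc1ccccc1)C(C(=O)Nc1ccccc1)N2` has not been measured. It differs from compound 2 in one place: a group of 6 heavy atoms (6 carbon; one six-membered aromatic ring of carbon only) in place of a group of 11 heavy atoms (11 carbon; one five-membered non-aromatic ring of carbon only, one six-membered aromatic ring of carbon only), on an amide-type nitrogen. Among the compounds with values here, no measured pair shows the effect of such a change, and all three known numbers sit close together, so no shift beyond the scatter is expected. Compound 4 is expected to give 38000 nM, within the range 13000 nM to 110000 nM. The step in this assay is expected to be a 1.3-fold higher number from compound 2 to compound 4 (0.10 log units; within the scatter), essentially none.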

Compound 4, half-maximal inhibitory concentration: > 64000 nM
Compound 4 gave a limit, no number (the forecaster's own chance of this, stated with the estimate: 20%); at least 1.6-fold (0.22 log units) between middle value and limit.
By their numbers in this assay, from the lowest: compounds 2, 1 and 3 (each within the scatter of the next). At a limit, above all of these: compound 4.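

On the amide-type nitrogen, replacing the group with the five-membered ring by phenyl gives in this assay an at least 2.1-fold higher number from compound 2 to compound 4 (0.32 log units; beyond the scatter). Going by these compounds alone, this is the first single-place step in the set, and it shows that the number responds to the group at this position. Compound 4 stands at a limit, not a number, so the full size of the step stays unknown: the limit of > 64000 nM in this assay, at which 1 of the 4 values shown sits.

Which part of the larger group matters remains open. So does whether phenyl on a longer chain, or an amine there, would restore the number of compound 2.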